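This account rests on a few compounds, and the source may have more. Where it says the series, first, only, none or still open, it means among the compounds named here.

Measured so far:
Compound 1, `CC(=O)Nc1ccc2nc(SCC(=O)NCc3ccccc3)sc2c1`: 9200 nM
Compound 2, `COc1ccc(CNC(=O)CSc2nc3ccc(NC(C)=O)cc3s2)cc1`: 11200 nM
Compound 3, `O=C(CSc1nc2ccc(NC(=O)c3ccc([N+](=O)[O-])cc3)cc2s1)NCc1ccccc1`: compound 3 reaches only the limit > 100000 nM

In a functional assay on HepG2 cells (Homo sapiens) for cytotoxicity, read by MTT assay, with a stated time of 48 h (on this read-out lower numbers stand for stronger inhibition and higher numbers for weaker inhibition), compound 1 gives 9200 nM and compound 2 gives 11200 nM. The two are separated by methoxy in place of hydrogen on an aromatic carbon, and the step is a 1.2-fold higher number from compound 1 to compound 2 (0.09 log units; within the scatter). Compound 3 gives only a limit of the assay, > 100000 nM. Its core differs from the core of compound 1 by 4-nitrophenyl in place of methyl on a carbonyl carbon, and the step is an at least 10-fold higher number from compound 1 to compound 3 (1.03 log units; beyond the scatter); this rests on (the limit of > 100000 nM in this assay, at which 1 of the 3 values shown sits).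

Compound 4, `COc1ccc(CNC(=O)CSc2nc3ccc(NC(=O)c4ccc([N+](=O)[O-])cc4)cc3s2)cc1`, has not yet been measured in this assay. It differs from compound 3 by methoxy in place of hydrogen on an aromatic carbon, the same change that separates compound 1 from compound 2, at a place that reads the same word for word. The step expected from compound 3 to compound 4 is a step that the limit leaves unreadable from compound 3 to compound 4, set beside a 1.2-fold higher number from compound 1 to compound 2 (0.09 log units; within the scatter), and it is expected to be small because compound 1 to compound 2 showed a 1.2-fold higher number from compound 1 to compound 2 (0.09 log units; within the scatter). Since compound 3 sits at a limit, compound 4 is likewise expected to be reported only as a limit. Compound 4 is estimated at 150000 nM, with a range from 60000 nM to 400000 nM.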

Compound 4, half-maximal inhibitory concentration: > 100000 nM
Compound 4: only a limit was reported; the forecaster's own chance of this, stated with the estimate: 80%; the middle value lies beyond the limit too.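

In this assay compound 4 gives only a limit of the assay, > 100000 nM, so the step that adds the methoxy group to compound 3 cannot be read. The other change, 4-nitrophenyl in place of methyl on a carbonyl carbon, can be followed onto the second core, where it gives an at least 8.9-fold higher number from compound 2 to compound 4 (0.95 log units; beyond the scatter), and it can be set against the earlier step: the same change on two cores in this assay, an at least 10-fold higher number (1.03 log units; beyond the scatter) from compound 1 to compound 3 and an at least 8.9-fold higher number (0.95 log units; beyond the scatter) from compound 2 to compound 4; the limit leaves it open whether they differ This shows that the change carries over in direction on both cores shown, with a step beyond the scatter each time, but it does not show how large either step really is or whether methoxy matters once the 4-nitrophenyl group is present, since these values rest on a limit: the limit of > 100000 nM in this assay, at which 2 of the 4 values shown sit.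

The compounds shown leave open whether the step belongs to the 4-nitrophenyl group itself or would also come with a plain phenyl, a 4-aminophenyl or a longer alkyl chain on that carbonyl carbon. They also leave open how a fluorine or a carboxylic acid would read in place of the methoxy group.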